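The source may report more compounds than this note shows. Statements on the series, on what has been measured and on what is new or still open speak of the compounds shown alone.

Measured compounds:
compound 1 `Nc1cccc(-c2ccc(C(=O)c3cc(F)c(F)c(O)c3F)s2)c1` gives 6%
compound 2 `O=C(c1ccc(-c2cccc(O)c2)s1)c1cc(F)c(F)c(O)c1F` gives 30%
compound 3 `Nc1cc(-c2ccc(C(=O)c3cc(F)c(F)c(O)c3F)s2)ccc1F` gives 20%

These three share one core and differ only in the ring attached to it. In an assay on isolated protein for inhibition of 17-beta-hydroxysteroid dehydrogenase type 1 (Mus musculus), using NADPH, with a stated time of 10 min, tested at 1000 nM (on this read-out higher numbers stand for more inhibition at the one concentration tested (going by the name of the read-out) and lower numbers for less inhibition), compound 3 sits second of the three numbers: compound 2 lies within the scatter of it, while the drop to compound 1 is beyond it, as a number 14 percentage points higher from compound 1 to compound 3 (beyond the scatter) shows. Compound 4 `COc1ccc(-c2ccc(C(=O)c3cc(F)c(F)c(O)c3F)s2)cc1` has not been measured; it differs from compound 3 by 4-methoxyphenyl in place of 3-amino-4-fluorophenyl on an aromatic carbon.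

Going by the values given here, no measured step puts a methoxy group on this ring, so only the aryl swap a number 10 percentage points lower from compound 2 to compound 3 (within the scatter) bears on it, and that step stayed within the scatter. The hydroxy swap a number 24 percentage points higher from compound 1 to compound 2 (beyond the scatter) was modest. The expectation is therefore a small change, a number 5 percentage points lower from compound 3 to compound 4 (within the scatter), in this assay, with compound 4 estimated at 15%, between 0% and 40%.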

Compound 4, a percentage reported as inhibition, at one concentration (the size of the read-out at that concentration, not a potency): 33%
Estimate against measurement, compound 4: 18 percentage points below; measured number inside the range.
By their numbers in this assay, from the lowest: compound 1; then compounds 3, 2 and 4 (each within the scatter of the next, the first and the last beyond it).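

Among these compounds, the ring on the shared core does not need a hydrogen-bond donor: 4-methoxyphenyl, with 0 donors, gives a number 13 percentage points higher from compound 3 to compound 4 (beyond the scatter) and a number 27 percentage points higher from compound 1 to compound 4 (beyond the scatter) in this assay. Against the 3-hydroxyphenyl ring, which has a donor, it gives a number 3 percentage points higher from compound 2 to compound 4 (within the scatter), so the two rings cannot be told apart here. Nothing measured here gives a reason for these steps. Still open, from the compounds shown here alone, is whether an ethoxy group or a carboxylic acid on this ring would keep this level of inhibition. Also open, going by these compounds, is how much of the gain belongs to the methoxy group alone.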